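Fluoro on the hydroxy compound: expected step

The source may report more compounds than this note shows. Statements on the series, on what has been measured and on what is new or still open speak of the compounds shown alone.

In a functional assay on MCF7 cells (Homo sapiens) for inhibition, read by sulforhodamine B assay (on this read-out higher numbers stand for weaker inhibition of growth and lower numbers for stronger inhibition of growth), compound 3 (`Oc1cccc2[nH]c(-c3ccc(-c4ccc(-c5ccccc5)cc4)cc3)nc12`) gives 2200 nM, the lowest of the three numbers, against compound 1 (`c1ccc(-c2ccc(-c3ccc(-c4nc5ccccc5[nH]4)cc3)cc2)cc1`) at 39200 nM and compound 2 (`Fc1ccc(-c2ccc(-c3ccc(-c4nc5ccccc5[nH]4)cc3)cc2)cc1`) at 36200 nM in this series. Compound 4 (`Oc1cccc2[nH]c(-c3ccc(-c4ccc(-c5ccc(F)cc5)cc4)cc3)nc12`) differs from compound 3 by one change: fluoro in place of hydrogen on an aromatic carbon, para to a large group. Among the compounds with values here, the closest precedent is the same replacement, a 1.1-fold lower number from compound 1 to compound 2 (0.03 log units; within the scatter), while the large 18-fold lower number from compound 1 to compound 3 (1.25 log units; beyond the scatter) comes from hydroxy and says nothing direct about fluoro. Going by these compounds, whether the fluoro result carries over to the hydroxy compound is untested. The expected change in this assay is a 1.0-fold lower number from compound 3 to compound 4 (0.02 log units; within the scatter), which is no step beyond the scatter. Compound 4 is estimated at 2100 nM, with 900 nM to 5000 nM as the expected range.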

Compound 4, concentration for 50% growth inhibition: 3010 nM
For compound 4 the middle estimate is 1.4-fold (0.16 log units) below the measured one; low and high end bracket the measured number.
By their numbers in this assay, from the lowest: compounds 3 and 4 (each within the scatter of the next); then compounds 2 and 1 (each within the scatter of the next).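

On the hydroxy core in this assay, phenyl to 4-fluorophenyl again stays within the scatter, with a 1.4-fold higher number from compound 3 to compound 4 (0.14 log units; within the scatter), so the fluoro change reads alike on both cores: the same change on two cores in this assay, a 1.1-fold lower number (0.03 log units; within the scatter) from compound 1 to compound 2 and a 1.4-fold higher number (0.14 log units; within the scatter) from compound 3 to compound 4, 1.5-fold (0.17 log units) apart, within the scatter of two such steps.

The hydroxy gain also holds with fluoro in place, with a 12-fold lower number from compound 2 to compound 4 (1.08 log units; beyond the scatter), and its size reads alike with and without fluoro: the same change on two cores in this assay, an 18-fold lower number (1.25 log units; beyond the scatter) from compound 1 to compound 3 and a 12-fold lower number (1.08 log units; beyond the scatter) from compound 2 to compound 4, 1.5-fold (0.17 log units) apart, within the scatter of two such steps.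

Open, going by these compounds, is whether an amine or a carboxylic acid at this place, para to a large group, would move the number. Also open, on these data alone, is whether a methoxy group could replace the hydroxy and keep the gain.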